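Methoxy for trifluoromethyl on two thioether cores

The source may hold more compounds than are shown below. What is called first, only, known or untested is meant among the compounds shown, and "the series" means these compounds.

Compound 1 `C#CCNC1CCc2c(SCCc3cccc(C(F)(F)F)c3)cccc21` and compound 2 `C#CCNC1CCc2c(SCCc3cccc(OC)c3)cccc21` share one core and differ only in methoxy in place of trifluoromethyl on an aromatic carbon. In an ADME assay on isolated protein for inhibition of Amine oxidase [flavin-containing] B (Homo sapiens) (a lower number here means a stronger inhibitor, a higher number a weaker inhibitor), compound 1 gives 280 nM, and compound 2 gives 3820 nM; the step is a 14-fold higher number from compound 1 to compound 2 (1.13 log units; beyond the scatter). Compound 3 `C#CCNC1CCc2c(SCc3cccc(C(F)(F)F)c3)cccc21` carries the trifluoromethyl on another core; how the two cores differ is not broken down here. In this assay compound 3 gives 7710 nM. Compound 4 `C#CCNC1CCc2c(SCc3cccc(OC)c3)cccc21` is not yet measured; it differs from compound 3 by methoxy in place of trifluoromethyl on an aromatic carbon, the same change that separates compound 1 from compound 2. The step of a 7.8-fold higher number from compound 3 to compound 4 (0.89 log units; beyond the scatter) is expected in this assay to lie beside the earlier one, because the same change gave a 14-fold higher number from compound 1 to compound 2 (1.13 log units; beyond the scatter), though the core of compound 3 is not the core of compound 1 and the transfer is uncertain. The estimate for compound 4 in this assay is 60000 nM.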

Compound 4, half-maximal inhibitory concentration: 1520 nM
Compound 4: the middle estimate sits 39-fold (1.60 log units) above what was measured; measured number below the stated range.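

In this assay the change of trifluoromethyl to methoxy gives a 5.1-fold lower number from compound 3 to compound 4 (0.71 log units; beyond the scatter), so neither its size nor its direction carries over from one core to the other: the same change on two cores in this assay, a 14-fold higher number (1.13 log units; beyond the scatter) from compound 1 to compound 2 and a 5.1-fold lower number (0.71 log units; beyond the scatter) from compound 3 to compound 4, 69-fold (1.84 log units) apart, beyond the scatter of two such steps On these two pairs, the change cannot be treated as a fixed increment, and its outcome depends on the core that carries it. The pairs do not show why the steps part ways, and two cores give no rule for predicting the step on a third.

Still open, on these data alone, is whether a chlorine or a nitrile in the same place would follow trifluoromethyl or methoxy on each core. Also open, as far as these compounds go, is how the change would behave on a longer thioether chain.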